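Carbamoyl Exchanged for (Acetyl(methyl)amino)methyl on the Shared Core

A few compounds are considered here, and "the series" means these few. Any claim that something is new, unique, unknown or untested is made for them only; others in the source may bear on it.

Measured so far in a toxicity assay on CCRF-CEM cells (Homo sapiens) for cytotoxicity; on this read-out lower numbers stand for higher toxicity in this test and higher numbers for lower toxicity in this test:
Compound 1, `CNc1cccc2c1nc(-c1c(F)cccc1F)n2Cc1c(F)cccc1F`, gives 27.2 uM.
Compound 2, `NC(=O)c1cccc2c1nc(-c1c(F)cccc1F)n2Cc1c(F)cccc1F`, reaches only the limit of the test, > 100 uM.

Compound 2 therefore stands at the limit of > 100 uM in this assay, at which 1 of the 2 values shown sits, and its true number is not known; what is known is that it lies on the less toxic side of compound 1. Within the data shown here, the single measured step, an at least 3.6-fold higher number from compound 1 to compound 2 (0.56 log units; beyond the scatter), is the only one that bears on the next change, and it shows that replacing the small methylamino group on the shared core moved the read-out out of the measurable range.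

Compound 3, `CC(=O)N(C)Cc1cccc2c1nc(-c1c(F)cccc1F)n2Cc1c(F)cccc1F`, carries (acetyl(methyl)amino)methyl in place of carbamoyl on an aromatic carbon. This change again removes the carbamoyl group, but in the direction of a larger group on the same carbon, so the measured step gives a direction only loosely. Among the measured compounds shown here, no other pair speaks to it. For compound 3 the expected value in this assay is 70 uM, with a range from 25 uM to 150 uM. The step from compound 2 this implies is expected to be an at least 1.4-fold lower number from compound 2 to compound 3 (0.15 log units; that floor lies within the scatter), and a result at the limit again is quite possible.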

Compound 3, half-maximal toxic concentration: 20.6 uM
Beside the measured number, compound 3's estimate is 3.4-fold (0.53 log units) above it; measured number outside the range, below it.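

The change from carbamoyl to (acetyl(methyl)amino)methyl on this aromatic carbon brings the read-out in this assay back into the measurable range, with an at least 4.8-fold lower number from compound 2 to compound 3 (0.68 log units; beyond the scatter). The earlier compounds shown here showed only that leaving methylamino for carbamoyl moved the number up to the limit of the test; this result shows that the move can be undone at the same carbon by a group that is not methylamino. With a 1.3-fold lower number from compound 1 to compound 3 (0.12 log units; within the scatter), methylamino and (acetyl(methyl)amino)methyl cannot be told apart in this test, although they differ in build, so among the three groups shown, carbamoyl alone stands apart, and the higher number does not simply follow from any change at this carbon.

As far as these compounds go, compound 2 remains a limit and not a number, so the true size of its steps to the other two compounds stays unknown: the limit of > 100 uM in this assay, at which 1 of the 3 values shown sits. Also open is whether a carboxylic acid, a methyl ester or an aminomethyl group on this carbon would side with compound 2 or with compound 1 and compound 3, and so which feature of carbamoyl sets it apart.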